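Chloro for methyl on the weak end of the series

This account rests on a few compounds, and the source may have more. Where it says the series, first, only, none or still open, it means among the compounds named here.

Measured in a functional assay on A549 cells (Homo sapiens) for inhibition, read by MTT assay, with a stated time of 72 h; on this read-out higher numbers stand for weaker inhibition and lower numbers for stronger inhibition:
Compound 1 `Cc1ccccc1-c1cc(C(=O)N2CCC3(CC2)CC(=O)c2nn(C(C)(C)C)cc2O3)c2ccccc2n1`: 1880 nM
Compound 2 `Cc1cc(C(=O)N2CCC3(CC2)CC(=O)c2nn(C(C)(C)C)cc2O3)c2ccccc2n1`: > 10000 nM

Compound 2 has no number, only a limit of the assay: > 10000 nM. It therefore sits at the limit of > 10000 nM in this assay, at which 1 of the 2 values shown sits.

Compound 3 `CC(C)(C)n1cc2c(n1)C(=O)CC1(CCN(C(=O)c3cc(Cl)nc4ccccc34)CC1)O2` is compound 2 with chloro in place of methyl on an aromatic carbon, next to the ring nitrogen (chloro in place of methyl on an aromatic carbon). The core and the amide are unchanged.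

Going by the values given here, one measured step bears on this place. It is an at least 5.3-fold higher number from compound 1 to compound 2 (0.72 log units; beyond the scatter), with methyl in place of 2-methylphenyl on that same carbon. So the group here can matter in this assay, but that exchange is much larger than the present one. Among the compounds with values here, no measured step shows what chloro does here.

Compound 3 is therefore expected to stay close to compound 2, with no step beyond the scatter. Nor is it expected to approach compound 1, which gives 1880 nM. The expected step, as estimated, is an at least 1.1-fold lower number from compound 2 to compound 3 (0.04 log units; that floor lies within the scatter). For compound 3 the estimate is 9000 nM, with an expected range of 3500 nM to 25000 nM.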

Compound 3, half-maximal inhibitory concentration: 7170 nM
Compound 3: middle estimate off by 1.3-fold (0.10 log units), on the high side; measured number inside the range.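

In this assay compound 2 is held at a limit of the assay, not at a number: the limit of > 10000 nM in this assay, at which 1 of the 3 values shown sits.

Against that limit, chloro in place of methyl gives an at least 1.3-fold lower number from compound 2 to compound 3 (0.14 log units; that floor lies within the scatter); with that floor inside the scatter, this exchange on the aromatic carbon next to the ring nitrogen is not shown to matter, although the real gap could be larger. Going by these compounds alone, the new pair gives the first step at this carbon between two measured numbers, a 3.8-fold higher number from compound 1 to compound 3 (0.58 log units; beyond the scatter), and it shows that the 2-methylphenyl compound keeps a lower number than the chloro compound by a margin beyond the scatter, without relying on a limit.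

The compounds shown leave open whether the advantage of compound 1 belongs to the aromatic ring as such or to its methyl, a question that plain phenyl at this carbon would address. They also leave open how an amine or a methoxy group would behave here, and whether any small group can move the number clearly away from that of compound 3.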